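The compounds below may be only part of what the source reports. "The series", "measured", "known", "first", "only" and "open" are said of these compounds alone.

Working notes on the series. Compound 1 `COc1cccc(C(=O)N2CCN(CC(=O)N3CCN(CCCc4c[nH]c5ccccc45)CC3)CC2)c1` and compound 2 `O=C(CN1CCN(C(=O)c2cccc(Br)c2)CC1)N1CCN(CCCc2c[nH]c3ccccc23)CC1` share one core; compound 3 `COc1ccc(C(=O)N2CCN(CC(=O)N3CCN(CCCc4c[nH]c5ccc(F)cc45)CC3)CC2)cc1` and compound 4 `O=C(CN1CCN(C(=O)c2ccc(Br)cc2)CC1)N1CCN(CCCc2c[nH]c3ccc(F)cc23)CC1` share another. How the core of compound 3 differs from the core of compound 1 is not broken down here.

In an ADME assay on HEK293 cells (Homo sapiens) for cytotoxicity, read by MTT assay, with a stated time of 72 h (a lower number here means a stronger inhibitor, a higher number a weaker inhibitor), compound 1 gives 143000 nM. In this assay compound 2 gives 80700 nM. The change between them is bromo in place of methoxy on an aromatic carbon, and the step it made was a 1.8-fold lower number from compound 1 to compound 2 (0.25 log units; within the scatter). In this assay compound 3 gives 141000 nM; against both compound 1 and compound 2 this value lies within the scatter, so no order among the three is read from these numbers.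

Compound 4 is not yet measured. Its difference from compound 3 is bromo in place of methoxy on an aromatic carbon. This is the same kind of change as that from compound 1 to compound 2, not the same one: in compound 2 the bromo sits meta to a large group, in compound 4 it sits para to a large group. For the measured compounds named here, only one measured pair shows this kind of change, and its step stayed within the scatter; no second pair weighs against it.

The expectation for compound 4 rests on that single pair, a 1.8-fold lower number from compound 1 to compound 2 (0.25 log units; within the scatter), applied to the value of compound 3. A step of a 1.7-fold lower number from compound 3 to compound 4 (0.22 log units; within the scatter) in this assay is expected. For compound 4 the estimate in this assay is 85000 nM. The expected range for compound 4 runs from 40000 nM to 180000 nM.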

Compound 4, half-maximal inhibitory concentration: 60500 nM
Estimate against measurement, compound 4: 1.4-fold (0.15 log units) above; the range from low to high includes it.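

In this assay, bromo in place of methoxy on the core of compound 3 gives a 2.3-fold lower number from compound 3 to compound 4 (0.37 log units; beyond the scatter), a modest step that goes the same way as the one seen on the core of compound 1. Set side by side, the two steps do not differ, so in these two pairs the change carries from one core to the other without a detectable difference in size: the same change on two cores in this assay, a 1.8-fold lower number (0.25 log units; within the scatter) from compound 1 to compound 2 and a 2.3-fold lower number (0.37 log units; beyond the scatter) from compound 3 to compound 4, 1.3-fold (0.12 log units) apart, within the scatter of two such steps

For the compounds shown here, this does not show a general rule for the series, since it rests on only two pairs, one of which stayed within the scatter, and the bromo does not occupy the same place on the aromatic ring in the two pairs, so any influence of position and any influence of core cannot be told apart here; nor does it give any cause for the step.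

The compounds shown leave open whether the step would be the same with the 4-bromophenyl group on the core of compound 1, which would separate place on the ring from core. They also leave open whether another replacement for methoxy at that place, such as chloro, an amine or a carboxylic acid, would move the number the same way.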